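The compounds below may be only part of what the source reports. "The series", "measured", "known", "first", "only" and "open" are said of these compounds alone.

Within the data shown here, compound 3 `COc1cccc(CNCCCNc2ccnc3cc(Cc4cc(C)cc(C)c4)ccc23)c1O` is one of three compounds measured in an ADME assay for permeability, using PAMPA, with a stated time of 30 min, at pH 7.4; a higher number here means that the compound crosses the layer faster, a lower number that the compound crosses the layer more slowly. In this assay compound 3 gives 23 10^-6 cm/s, level with compound 1 `COc1cccc(CNCCCNc2ccnc3cc(Cc4cccc(C(F)(F)F)c4)ccc23)c1O`, which gives 23 10^-6 cm/s; these two share the lowest numbers of the set. Among the measured compounds shown here, the single measured step, no change at the digits printed from compound 1 to compound 3 (within the scatter), shows that swapping one aromatic group for another on the saturated chain carbon left the number where it was. For the measured compounds named here, compound 2 `COc1ccc(F)cc1CNCCCNc1ccnc2cc(-c3ccc(C(C)(C)C)cc3)ccc12` gives 237 10^-6 cm/s, far above both, but compound 2 differs from compound 3 in more than one place, so no single step can be drawn from it.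

Compound 4 `COc1cccc(CNCCCNc2ccnc3cc(-c4ccc(C(C)(C)C)cc4)ccc23)c1O` has not yet been measured. The change from compound 3 is 4-(tert-butyl)phenyl in place of 3,5-dimethylbenzyl on an aromatic carbon. Going by the values given here, the group that enters is the one found in compound 2, while the rest of compound 4 follows compound 3 rather than compound 2. The step from compound 1 to compound 3 gave no movement, so the only pointer toward a larger number is the value of compound 2. An increase beyond the scatter is therefore expected, but smaller than the full gap to compound 2: the estimated step is a 2.8-fold higher number from compound 3 to compound 4 (0.45 log units; beyond the scatter). Compound 4 is expected to give about 65 10^-6 cm/s, within a range from 25 10^-6 cm/s to 170 10^-6 cm/s.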

Compound 4, apparent permeability: 237 10^-6 cm/s
For compound 4 the middle estimate is 3.6-fold (0.56 log units) below the measured one; measured number outside the range, above it.
By their numbers in this assay, from the lowest: compounds 1 and 3 (each within the scatter of the next); then compounds 2 and 4 (each within the scatter of the next).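

In this assay the aromatic carbon of the shared core proves to be a sensitive position: 4-(tert-butyl)phenyl in place of 3,5-dimethylbenzyl gives a 10-fold higher number from compound 3 to compound 4 (1.01 log units; beyond the scatter) and, in place of 3-(trifluoromethyl)benzyl, gives a 10-fold higher number from compound 1 to compound 4 (1.01 log units; beyond the scatter) in the same assay. On the saturated chain carbon bound to an amine nitrogen, 2-hydroxy-3-methoxyphenyl in place of 5-fluoro-2-methoxyphenyl gives no change at the digits printed from compound 2 to compound 4 (within the scatter) for these two compounds, so the number here follows the group on the aromatic carbon. Nothing measured here explains why this change moves the number.

The change joins the ring directly to the core and adds the tert-butyl group in one step, so the two effects cannot be separated. A plain phenyl group at this position would help tell them apart.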